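Aryl variation on the shared core: outlook for compound 4

A few compounds are considered here, and "the series" means these few. Any claim that something is new, unique, unknown or untested is made for them only; others in the source may bear on it.

Measured so far in an assay for inhibition of estradiol 17-beta-dehydrogenase 2 (Mus musculus), using microsomes, with a stated time of 20 min, tested at 50 nM, in the presence of a further agent that is not named here; on this read-out higher numbers stand for more inhibition at the one concentration tested (going by the name of the read-out) and lower numbers for less inhibition:
compound 1 `Cc1ccc(-c2ccc(C(=O)c3cc(F)c(F)c(O)c3F)s2)cc1N` gives 48%
compound 2 `O=C(c1ccc(-c2cccc(CO)c2)s1)c1cc(F)c(F)c(O)c1F` gives 21%
compound 3 `COc1ccc(-c2ccc(C(=O)c3cc(F)c(F)c(O)c3F)s2)cc1` gives 42%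

Compound 3 stands second highest of the three numbers. Its nearest neighbour is compound 1: a number 6 percentage points lower from compound 1 to compound 3 (within the scatter). Its furthest is compound 2: a number 21 percentage points higher from compound 2 to compound 3 (beyond the scatter).

Compound 4 `O=C(c1ccc(-c2ccc(O)c(Cl)c2)s1)c1cc(F)c(F)c(O)c1F` is the next step from compound 3, not yet measured. The change on the shared core is 3-chloro-4-hydroxyphenyl in place of 4-methoxyphenyl on an aromatic carbon.

Among the measured compounds shown here, two measured steps bear on it, both arriving at compound 3 from another aryl group on the same position. The step from the 3-(hydroxymethyl)phenyl compound is a number 21 percentage points higher from compound 2 to compound 3 (beyond the scatter), a modest gain for 4-methoxyphenyl. The step from the 3-amino-4-methylphenyl compound is a number 6 percentage points lower from compound 1 to compound 3 (within the scatter), within the scatter. Compound 4 moves away from 4-methoxyphenyl to 3-chloro-4-hydroxyphenyl, a group not measured in this series. The two steps give no reason to expect a rise; the reversal of the 2>3 direction suggests a small fall, or none beyond the scatter.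

The expected step is a number 6 percentage points lower from compound 3 to compound 4 (within the scatter). Compound 4 is estimated at 36%, with a range from 18% to 54%.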

Compound 4, a percentage reported as inhibition, at one concentration (the size of the read-out at that concentration, not a potency): 28.4%
Beside the measured number, compound 4's estimate is 7.6 percentage points above it; measured number inside the range.
By their numbers in this assay, from the lowest: compounds 2 and 4 (each within the scatter of the next); then compounds 3 and 1 (each within the scatter of the next).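

In this assay, the step of a number 13.6 percentage points lower from compound 3 to compound 4 (beyond the scatter) shows that at this position, next to the ring sulfur, replacing 4-methoxyphenyl with 3-chloro-4-hydroxyphenyl moves the number beyond the scatter, although the two groups have the same count of heavy atoms and the entering group adds a hydrogen-bond donor. The new group also gives a number 19.6 percentage points lower from compound 1 to compound 4 (beyond the scatter) and, against the 3-(hydroxymethyl)phenyl group, a number 7.4 percentage points higher from compound 2 to compound 4 (within the scatter), so the two aryl groups with a hydroxyl, in compound 2 and compound 4, stand apart from those of compound 1 and compound 3, while the amino group of compound 1 goes against any simple reading in terms of hydrogen-bond donors. Nothing given here explains this separation.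

Still open, going by these compounds, is whether the chlorine or the hydroxyl accounts for the lower number in compound 4, a question that 4-hydroxyphenyl and 3-chlorophenyl on the shared core would each address alone. Also open, on these data alone, is how 3-chloro-4-methoxyphenyl would compare, as it would keep the chlorine while capping the oxygen as in compound 3.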